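The source may hold more compounds than are shown below. What is called first, only, known or untested is meant among the compounds shown, and "the series" means these compounds.

Notes on the series. In a functional assay for agonist activity at G protein-coupled receptor 88 (Homo sapiens), read by HTRF and cAMP accumulation (a higher number here means that more compound is needed for the effect, a lower number that less compound is needed), compound 3 `CC(C)C[C@H](N)CN(C(=O)[C@@H]1C[C@H]1c1ccccc1)c1ccc(-c2ccsc2)cc1` gives 1200 nM, the lowest of the three numbers recorded so far. Compound 1 `CC[C@H](C)[C@H](N)CN(C(=O)[C@@H]1C[C@H]1c1cccnc1)c1ccc(-c2ccccc2)cc1` gives 1500 nM in this assay, a number within the usual scatter of compound 3, so no order between these two can be claimed. Compound 2 `CC(C)C[C@H](N)CN(C(=O)[C@@H]1C[C@H]1c1ccccc1)c1ccccc1-c1ccccc1` gives 6200 nM in this assay, and this lies beyond the scatter from compound 3. Within the data shown here, compound 1 and compound 2 each differ from compound 3 in more than one place, so no single step separates them.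

Compound 4 `Cc1ccccc1-c1ccc(N(C[C@@H](N)CC(C)C)C(=O)[C@@H]2C[C@H]2c2ccccc2)cc1` has not yet been measured. It differs from compound 3 by 2-methylphenyl in place of thiophen-3-yl on an aromatic carbon. Among the measured compounds shown here, no pair of measured compounds isolates this change, so nothing measured speaks to its size or direction. The expected step is therefore a 1.5-fold higher number from compound 3 to compound 4 (0.18 log units; within the scatter), no larger than the scatter. Compound 4 is expected to give about 1800 nM in this assay, with a range from 600 nM to 6000 nM.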

Compound 4, half-maximal effective concentration: 3400 nM
Estimate against measurement, compound 4: 1.9-fold (0.28 log units) below; low and high end bracket the measured number.
By their numbers in this assay, from the lowest: compounds 3 and 1 (each within the scatter of the next); then compounds 4 and 2 (each within the scatter of the next).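

Among these compounds, at the aromatic carbon para to a large group, 2-methylphenyl in place of thiophen-3-yl gives the first single-change step in this assay: a 2.8-fold higher number from compound 3 to compound 4 (0.45 log units; beyond the scatter). The step is modest but beyond the scatter, so the number at this position depends on which aromatic group is attached. Here the entering group, with 7 heavy atoms against 5, gives the higher number, and no measurement available bears on why.

The change swaps a five-membered ring with a sulfur atom for a six-membered carbon ring carrying a methyl group, so this one step leaves open which of those differences sets its size. Also open, as far as these compounds go, is how a pyridine ring or a methoxy-substituted phenyl ring at this position would read on the same core.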